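The compounds below may be only part of what the source reports. "The series", "measured", "known", "first", "only" and "open" are said of these compounds alone.

Of the compounds shown here, three that share one core have been measured so far. Compound 1 `Nc1cc(N)c2nc(-c3ccccc3)c(Sc3ccc(F)cc3)nc2c1` gives 31600 nM in a functional assay on U-251 cells (Homo sapiens) for inhibition, read by sulforhodamine B assay, with a stated time of 48 h; on this read-out lower numbers stand for stronger inhibition of growth and higher numbers for weaker inhibition of growth. Compound 2 `COc1cc(CNc2nc3cc(N)cc(N)c3nc2-c2ccccc2)cc(OC)c1OC`, which carries a different group on the same core, gives 6310 nM in this assay. For the measured compounds named here, of the two numbers known, compound 2 stands at the lower one, meaning stronger growth inhibition, and compound 1 sits higher by a margin beyond the usual scatter. Compound 3 `CCOC(=O)[C@H](CCC(=O)O)NC(=O)c1ccc(Oc2nc3cc(N)cc(N)c3nc2-c2ccccc2)cc1` gives < 100000 nM in this assay, which is the limit of < 100000 nM in this assay, at which 1 of the 3 values shown sits; that value is a limit of the assay and not a number.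

Compound 4 `COc1ccc(CNc2nc3cc(N)cc(N)c3nc2-c2ccccc2)cc1OC` has not yet been measured. It differs from compound 2 in one place: hydrogen in place of methoxy on an aromatic carbon. Going by the values given here, no step between two measured compounds of this kind is available to guide an expectation, so the guess rests on the small size of the change. The expected step of a 1.3-fold higher number from compound 2 to compound 4 (0.10 log units; within the scatter) is modest, leaning toward slightly weaker inhibition but hardly beyond the scatter. Compound 4 is expected to give about 8000 nM in this assay, within a range from 3000 nM to 25000 nM.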

Compound 4, concentration for total growth inhibition: 38900 nM
For compound 4 the middle estimate is 4.9-fold (0.69 log units) below the measured one; the whole stated range lies below it.
By their numbers in this assay, from the lowest: compound 2; then compounds 1 and 4 (each within the scatter of the next).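

In this assay the exchange of methoxy for hydrogen on this aromatic carbon gives a 6.2-fold higher number from compound 2 to compound 4 (0.79 log units; beyond the scatter) and so means clearly weaker growth inhibition. For the compounds shown here, the earlier compounds differed from one another in more than one place, so this is the first change whose size can be read on its own. It shows that a loss of only two heavy atoms, at a place ortho to a methoxy group and meta to a large group, can matter, although this rests on a single pair of compounds.

Still open, going by these compounds, is what a hydroxyl, a fluorine atom or an ethoxy group on this same carbon would do, and whether the other two methoxy groups count as much as this one. Nothing among the values shown gives a measured reason for the size of this step.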